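This account rests on a few compounds, and the source may have more. Where it says the series, first, only, none or still open, it means among the compounds named here.

Working notes on the series. Compound 1 `NS(=O)(=O)c1ccc(Nc2nc(N/N=C/c3ccc(C(F)(F)F)cc3)nc(Nc3ccccc3)n2)cc1` and compound 2 `Cc1nn(-c2ccccc2)cc1/C=N/Nc1nc(Nc2ccccc2)nc(Nc2ccc(S(N)(=O)=O)cc2)n1` share one core and differ only in the group on the carbon with a double bond to nitrogen. In a functional assay on OVCAR-8 cells (Homo sapiens) for inhibition, read by sulforhodamine B assay, with a stated time of 48 h (a lower number here means a stronger inhibitor of growth, a higher number a weaker inhibitor of growth), compound 1 gives 2830 nM. In this assay compound 2 gives 2050 nM. For the measured compounds named here, compound 2 thus stands at the lowest of the two numbers so far, although a 1.4-fold lower number from compound 1 to compound 2 (0.14 log units; within the scatter) lies within the scatter, so no order between the two can be read from these values.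

Compound 3 `NS(=O)(=O)c1ccc(Nc2nc(N/N=C/c3ccccn3)nc(Nc3ccccc3)n2)cc1` is the next member. It differs from compound 2 by pyridin-2-yl in place of 3-methyl-1-phenyl-1H-pyrazol-4-yl on a carbon with a double bond to nitrogen. Going by the values given here, the only measured step that bears on this change is an exchange of the group at that same carbon, a 1.4-fold lower number from compound 1 to compound 2 (0.14 log units; within the scatter), which did not move the number beyond the scatter. Among the compounds with values here, on that basis no step beyond the scatter is expected in this assay for compound 3 in either direction, and a wide range is kept since only one such exchange has been measured. The step expected is a 1.2-fold higher number from compound 2 to compound 3 (0.09 log units; within the scatter). Compound 3 is estimated at 2500 nM, with a range from 900 nM to 7000 nM.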

Compound 3, concentration for 50% growth inhibition: 440 nM
Compound 3: middle estimate off by 5.7-fold (0.75 log units), on the high side; measured number below the stated range.
By their numbers in this assay, from the lowest: compound 3; then compounds 2 and 1 (each within the scatter of the next).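

For the compounds shown here, the position on the carbon with a double bond to nitrogen is not indifferent to its group in this assay: the one exchange seen earlier stayed within the scatter, whereas pyridin-2-yl gives a 4.7-fold lower number from compound 2 to compound 3 (0.67 log units; beyond the scatter) and also a 6.4-fold lower number from compound 1 to compound 3 (0.81 log units; beyond the scatter) at this same carbon. Both steps lie beyond the scatter and end at compound 3, so the pyridin-2-yl compound stands apart from the two compounds that carry 3-methyl-1-phenyl-1H-pyrazol-4-yl and 4-(trifluoromethyl)phenyl, between which no order can be read. Among the three compounds, the change of group at this carbon can therefore move the number, although the exchange that leaves 3-methyl-1-phenyl-1H-pyrazol-4-yl also removes one of its two rings, and these compounds cannot separate that loss from the entry of the pyridine ring.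

Open, from the compounds shown here alone, is how phenyl without a substituent, pyridin-3-yl, pyridin-4-yl or a pyridin-2-yl ring bearing an amine would stand at this carbon, and so whether the lower number belongs to pyridin-2-yl alone. Going by these compounds alone, nothing measured so far explains the step to compound 3.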